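A few compounds are considered here, and "the series" means these few. Any claim that something is new, unique, unknown or untested is made for them only; others in the source may bear on it.

In an ADME assay on microsomes from liver (Rattus norvegicus) for metabolic stability, with a stated time of 30 min (on this read-out higher numbers stand for a more stable compound and lower numbers for a less stable compound), compound 1 (`Cc1cc(C(=O)c2cc(-c3ccc(Cl)cc3)n(-c3ccc(S(N)(=O)=O)cc3)c2C)ccc1Cl`) gives 38% and compound 2 (`COc1ccc(F)cc1C(=O)c1cc(-c2ccc(Cl)cc2)n(-c2ccc(S(N)(=O)=O)cc2)c1C`) gives 45% remaining, which places compound 2 within the scatter of compound 1. Compound 3 (`Cc1c(C(=O)N2CCCC2)cc(-c2ccc(Cl)cc2)n1-c1ccc(S(N)(=O)=O)cc1`) carries pyrrolidin-1-yl in place of 5-fluoro-2-methoxyphenyl on a carbonyl carbon. For the measured compounds named here, the one measured step that bears on this (a number 7 percentage points higher from compound 1 to compound 2 (within the scatter)) also changed the group on a carbonyl carbon, but it lay within the scatter and no measured compound carries pyrrolidin-1-yl, so no step beyond the scatter is expected. The estimated change in this assay (a number 3 percentage points lower from compound 2 to compound 3 (within the scatter)) is therefore small. Compound 3 is expected at 42% (estimated range 20% to 65%) with wide uncertainty.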

Compound 3, percent of the compound remaining: 31%
Compound 3: the middle estimate sits 11 percentage points above what was measured; low and high end bracket the measured number.
By their numbers in this assay, from the lowest: compounds 3, 1 and 2 (each within the scatter of the next, the first and the last beyond it).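

For the compounds shown here, with this assay, pyrrolidin-1-yl on the carbonyl carbon gives the first step at this position that lies beyond the scatter, a number 14 percentage points lower from compound 2 to compound 3 (beyond the scatter). Against the other aromatic group the same replacement does not, with a number 7 percentage points lower from compound 1 to compound 3 (within the scatter), so the reading of this change depends on which group it replaces. Nothing available gives a reason for this step.

As far as these compounds go, whether piperidine or morpholine on the same carbonyl carbon would read differently from pyrrolidin-1-yl remains open. So does the effect of an open-chain amine such as diethylamine there.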